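Replacing the acid of compound 1 with an alcohol

The compounds below may be only part of what the source reports. "The series", "measured", "known", "first", "only" and "open" are said of these compounds alone.

Compound 1 `N#Cc1ccc(OCc2ccsc2)cc1/C=C(/C(=O)O)c1ccccc1`: 80 nM
Compound 2 `N#Cc1ccc(OCc2ccsc2)cc1/C=C(/C(=O)O)c1ccccc1Cl`: 200 nM
Compound 3 `Cc1ccccc1/C(=C\c1cc(OCc2ccsc2)ccc1C#N)C(=O)O`: 300 nM

In an assay on A10 cells for binding affinity to Endothelin-1 receptor (Rattus norvegicus) (on this read-out lower numbers stand for stronger inhibition and higher numbers for weaker inhibition), compound 1 gives the lowest number of the three; compound 2 is a 2.5-fold higher number from compound 1 to compound 2 (0.40 log units; beyond the scatter) away and compound 3 a 3.8-fold higher number from compound 1 to compound 3 (0.57 log units; beyond the scatter). Compound 4 `N#Cc1ccc(OCc2ccsc2)cc1/C=C(/CO)c1ccccc1` keeps the core of compound 1 and changes one place: hydroxymethyl in place of carboxy on a double-bonded chain carbon bound to an aromatic carbon and a double-bonded chain carbon. Neither measured step touches that place; both alter the aromatic ring and leave the carboxy untouched, so they say little about this change. Among the measured compounds shown here, with no direct guide, the expectation for compound 4 rests on the thought that the carboxy is the only ionisable group here, and its removal is estimated to give a 38-fold higher number from compound 1 to compound 4 (1.57 log units; beyond the scatter), a weaker result. Compound 4 is therefore expected at about 3000 nM, somewhere between 500 nM and 30000 nM.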

Compound 4, half-maximal inhibitory concentration: 800 nM
For compound 4 the middle estimate is 3.8-fold (0.57 log units) above the measured one; measured number inside the range.
By their numbers in this assay, from the lowest: compound 1; then compounds 2 and 3 (each within the scatter of the next); then compound 4.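

In this assay, this first change at this position gives a 10-fold higher number from compound 1 to compound 4 (1.00 log units; beyond the scatter), so putting hydroxymethyl in place of carboxy weakens inhibition, yet compound 4 still gives a measurable number. The earlier steps shown here altered only the aromatic ring and showed nothing about this place. No measurement shown accounts for the shift, so its cause stays unknown.

Still open, going by these compounds, is how a primary amide or a methyl ester would fare at this place. Also open, on these data alone, is whether a chloro or methyl on the aromatic ring would shift the number the same way in the hydroxymethyl series.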